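Replacing 4-methoxyphenyl with 2,5-dihydroxyphenyl on a carbonyl carbon

The source may hold more compounds than are shown below. What is called first, only, known or untested is meant among the compounds shown, and "the series" means these compounds.

In a functional assay on MCF7 cells (Homo sapiens) for inhibition, read by MTT assay, with a stated time of 72 h (a lower number here means a stronger inhibitor, a higher number a weaker inhibitor), compound 1 `COc1ccc(C(=O)/C=C/c2cc(OC)c(OC)cc2OC)cc1` gives 33900 nM and compound 2 `COc1cc(OC)c(OC)cc1/C=C/C(=O)c1cc(Cc2ccccc2)cc(Cc2ccccc2)c1` gives 23300 nM as its reading. Among the measured compounds shown here, these two numbers lie within the scatter of each other, so compound 1 stands level with the only other compound measured so far. Compound 3 `COc1cc(OC)c(OC)cc1/C=C/C(=O)c1cc(O)ccc1O` has not yet been measured. For the measured compounds named here, it keeps the rest of compound 1 but carries 2,5-dihydroxyphenyl in place of 4-methoxyphenyl on a carbonyl carbon as the single change. Going by the values given here, no measured step between close relatives is available, so the expectation rests on this structural change alone. A modest move toward a lower number is expected in this assay and a result within the scatter would remain possible. The estimated change is a 2.8-fold lower number from compound 1 to compound 3 (0.45 log units; beyond the scatter) as a central expectation. For compound 3 the estimated value is 12000 nM with an expected range from 3000 nM to 40000 nM in repeated measurements.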

Compound 3, half-maximal inhibitory concentration: > 150000 nM
Compound 3 ended at the assay's limit; the forecaster's own chance of this, stated with the estimate: 10%; at least 12-fold (1.09 log units) between middle value and limit.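

In this assay, among the compounds shown here, this is the first change between close relatives that can be read, and it runs toward a weaker inhibitor: an at least 4.4-fold higher number from compound 1 to compound 3 (0.64 log units; beyond the scatter). Compound 3 gives > 150000 nM, which is a limit of the assay and not a number. At this place on the carbonyl carbon, then, 4-methoxyphenyl cannot be exchanged for 2,5-dihydroxyphenyl without a clear rise in the reading, and the full size of that rise stays unknown, the step being bounded only by the limit: the limit of > 150000 nM in this assay, at which 1 of the 3 values shown sits.

The two hydroxyl groups enter together, and the compounds shown leave open whether either one alone would go with the same rise. They also leave open how an amine or a carboxylic acid on this phenyl ring would read.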